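A Second Methyl on the Tolyl Arm of Compound 1

The source may hold more compounds than are shown below. What is called first, only, known or untested is meant among the compounds shown, and "the series" means these compounds.

Measured so far in an assay on Sf9 cells for inhibition of protein deacetylase HDAC6 (Homo sapiens), read by fluorescence, with a stated time of 40 min, tested at 100 nM; a higher number here means more inhibition at the concentration tested (going by the name of the read-out), a lower number less inhibition:
compound 1 `Cc1ccc(-n2nc(-c3ccccc3)nc2CNc2ccc(C(=O)NO)cc2)cc1`, giving 60.7%
compound 2 `CCc1ccc(-c2nc(CNc3ccc(C(=O)NO)cc3)n(-c3ccccc3)n2)cc1`, giving 54.6%
compound 3 `NNC(=O)c1ccc(NCc2nc(-c3ccccc3)nn2-c2ccccc2)cc1`, giving 10%

Compound 1 gives the highest of the three numbers, yet compound 2 lies within the usual scatter of it, so the two cannot be told apart. Compound 3 falls far below compound 1, a gap well beyond the scatter.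

Compound 4 `Cc1ccc(-n2nc(-c3ccccc3)nc2CNc2ccc(C(=O)NO)cc2)cc1C` is compound 1 with one change: methyl in place of hydrogen on an aromatic carbon. Read one bond further out, the 4-methylphenyl of compound 1 becomes 3,4-dimethylphenyl. Going by the values given here, no measured pair shows what such a change does here, so the expectation rests only on the change itself: a single carbon, no ring, no hydrogen-bond donors or acceptors, no charge, set ortho to a methyl group and meta to a large group. The step is expected to be small, within the scatter and in no certain direction, as a number 0.7 percentage points lower from compound 1 to compound 4 (within the scatter). Compound 4 is therefore estimated to give 60% in this assay, between 45% and 75%.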

Compound 4, a percentage reported as inhibition, at one concentration (the size of the read-out at that concentration, not a potency): 53%
Compound 4: the middle estimate sits 7 percentage points above what was measured; the range from low to high includes it.
By their numbers in this assay, from the lowest: compound 3; then compounds 4, 2 and 1 (each within the scatter of the next).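

In this assay, the first step measured on this arm reads (a number 7.7 percentage points lower from compound 1 to compound 4 (within the scatter)), so going from 4-methylphenyl to 3,4-dimethylphenyl gives a number that cannot be told apart from that of compound 1. At this one position, ortho to a methyl group and meta to a large group, the arm therefore accepts an added methyl with no change that can be read at the tested concentration. Nothing available explains this result, so it stands as an observation only.

Going by these compounds, a single methyl says little about other groups on this carbon, so it remains open whether an amine, a methoxy group or a carboxylic acid there would give a similar number. On these data alone, it is also open whether a longer chain, such as propyl, would fit equally well on this arm.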